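The compounds below may be only part of what the source reports. "The series", "measured", "known", "first", "only" and "open" are said of these compounds alone.

In an ADME assay for pharmacokinetics (a lower number here means that the compound disappears faster, a higher number that the compound lasts longer), compound 1 `CCOc1ccc(-n2nnc3c(C(N)=O)ncn3c2=O)cc1` gives 1.3 h, and compound 2 `NC(=O)c1ncn2c(=O)n(-c3ccccc3)nnc12` gives 0.383 h. Compound 3 `NC(=O)c1ncn2c(=O)n(-c3ccc([N+](=O)[O-])cc3)nnc12` gives < 0.0167 h, which is a limit of the assay and not a number. It stands lowest of the three, with two large steps leading to it: an at least 77-fold lower number from compound 1 to compound 3 (1.89 log units; beyond the scatter) and an at least 22-fold lower number from compound 2 to compound 3 (1.36 log units; beyond the scatter). Compound 4 `Cc1ccc(-n2nnc3c(C(N)=O)ncn3c2=O)cc1` has methyl in place of nitro on an aromatic carbon, para to a large group: methyl in place of nitro on an aromatic carbon. The same place also carries the modest step of a 3.4-fold lower number from compound 1 to compound 2 (0.53 log units; beyond the scatter). Among the measured compounds shown here, no measured step has methyl entering, so the expectation rests on these steps, and compound 4 is expected to fall in the range spanned by compound 2 and compound 1. A large upward step is expected: an at least 41-fold higher number from compound 3 to compound 4 (1.62 log units; beyond the scatter). For compound 4 the estimate is 0.7 h, with an expected range from 0.3 h to 1.5 h.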

Compound 4, half-life: 0.667 h
Estimate against measurement, compound 4: 1.0-fold (0.02 log units) above; low and high end bracket the measured number.
By their numbers in this assay, from the lowest: compounds 2, 4 and 1 (each within the scatter of the next, the first and the last beyond it). At a limit, below all of these: compound 3.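

In this assay, methyl at this place gives an at least 39-fold higher number from compound 3 to compound 4 (1.60 log units; beyond the scatter), so methyl does not share the low end seen with nitro. Against hydrogen the change is a 1.7-fold higher number from compound 2 to compound 4 (0.24 log units; within the scatter), and against ethoxy it is a 1.9-fold lower number from compound 1 to compound 4 (0.29 log units; within the scatter), so methyl cannot be told apart from either group, although hydrogen and ethoxy themselves differ beyond the scatter. Compound 3 stands at a limit of the assay and not at a number, so the first step gives only a lower bound: the limit of < 0.0167 h in this assay, at which 1 of the 4 values shown sits.

As far as these compounds go, whether nitro stands alone at this place stays open. So does whether an amine or a carboxylic acid there would stay with methyl, hydrogen and ethoxy or drop toward compound 3.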